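The compounds below may be only part of what the source reports. "The series", "measured", "known", "first", "only" and "open" are said of these compounds alone.

Working notes on the series. In a functional assay on MOLT-4 cells (Homo sapiens) for inhibition, read by MTT assay, with a stated time of 72 h (a higher number here means a weaker inhibitor, a lower number a stronger inhibitor), compound 1 (`COc1cc(NC(C)CCCNC(=O)Nc2ccc(Br)cc2)c2ncccc2c1`) gives 25000 nM, compound 2 (`COc1cc(NC(C)CCCNC(=O)Nc2ccc(F)cc2)c2ncccc2c1`) gives 24000 nM and compound 3 (`COc1cc(NC(C)CCCNC(=O)Nc2cc(C(F)(F)F)cc(C(F)(F)F)c2)c2ncccc2c1`) gives 12000 nM. Compound 2 lies within the scatter of both compound 1 and compound 3, so these numbers give it no separate rank.

Compound 4 (`COc1cc(NC(C)CCCNC(=O)Nc2ccc(Cl)cc2)c2ncccc2c1`) differs from compound 2 by one change, chloro in place of fluoro on an aromatic carbon, para to a large group. Within the data shown here, the only measured step at that place is a 1.0-fold lower number from compound 1 to compound 2 (0.02 log units; within the scatter), with fluoro in place of bromo, and it also exchanges one halogen for another. On that single step, no change beyond the scatter is expected in this assay. The expected step is a 1.0-fold lower number from compound 2 to compound 4 (0.02 log units; within the scatter). For compound 4 the estimated value is 23000 nM, with an expected range of 13000 nM to 40000 nM.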

Compound 4, half-maximal inhibitory concentration: 24000 nM
Compound 4: the middle estimate sits 1.0-fold (0.02 log units) below what was measured, and the stated range covers the measured number.
By their numbers in this assay, from the lowest: compounds 3, 2, 4 and 1 (each within the scatter of the next, the first and the last beyond it).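

In this assay the aromatic carbon para to a large group now carries a third halogen, with no change at the digits printed from compound 2 to compound 4 (within the scatter) for chloro in place of fluoro and a 1.0-fold lower number from compound 1 to compound 4 (0.02 log units; within the scatter) for chloro in place of bromo at the same place. Fluoro, chloro and bromo at this position therefore all lie within the scatter of one another, which extends the earlier single exchange to all three halogens and gives none of them a separate rank. No measurement at hand offers an explanation for this flat reading.

As far as these compounds go, whether any group other than a halogen at this place, such as methoxy, an amine or a carboxylic acid, would move the number beyond the scatter remains open.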